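Swapping Bromo for Chloro on an Ear-Inhibition Chalcone Series

A few compounds are considered here, and "the series" means these few. Any claim that something is new, unique, unknown or untested is made for them only; others in the source may bear on it.

Three compounds were tested in a functional assay on the whole organism (Ear) for inhibition, with Mus musculus as the target, with a stated time of 30 min, at a dose of 100 mg/kg by the intraperitoneal route; on this read-out lower numbers stand for less inhibition and higher numbers for more inhibition at the one dose given (going by the name of the read-out). Compound 1 `Cc1ccc(C(=O)/C=C/c2ccc(/C=N/NC(=O)c3ccccc3)cc2)c(C)c1` gives 0.18% in this assay. Compound 2 `N=C(N)N/N=C/c1ccc(/C=C/C(=O)c2cccc(Br)c2)cc1` gives 49.7% in this assay. Compound 3 `O=C(N/N=C/c1ccc(/C=C/C(=O)c2ccccc2F)cc1)c1ccncc1` gives 51.3% in this assay.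

On these numbers compound 2 stands second highest of the three. Its nearest neighbour is compound 3, whose value is only slightly higher and lies within the usual scatter of repeated measurements, so the two cannot be told apart. Its furthest neighbour is compound 1, whose value lies well below and beyond the scatter.

Compound 4 `N=C(N)N/N=C/c1ccc(/C=C/C(=O)c2cccc(Cl)c2)cc1` has not yet been measured. It differs from compound 2 in one place: chloro in place of bromo on an aromatic carbon. The change keeps a single halogen on the same aromatic carbon. Among the measured compounds shown here, no measured pair shows what such a change does here, so any expectation rests on compound 2 alone. The step from compound 2 to compound 4 is expected to be small, a number 3.7 percentage points lower from compound 2 to compound 4 (within the scatter), not beyond the scatter in either direction. Compound 4 is therefore estimated at 46%, with a range from 26% to 66%.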

Compound 4, a percentage reported as inhibition, in the whole organism at one dose (the size of the read-out at that dose, not a potency): 80.7%
Compound 4: middle estimate off by 34.7 percentage points, on the low side, and the stated range ends below it.
By their numbers in this assay, from the lowest: compound 1; then compounds 2 and 3 (each within the scatter of the next); then compound 4.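

In this assay, putting chloro in place of bromo on this aromatic carbon gives a number 31 percentage points higher from compound 2 to compound 4 (beyond the scatter), so the read-out here depends strongly on which single halogen the ring carries. The change is one heavy atom for one heavy atom, and no hydrogen-bond donor or acceptor enters or leaves, yet the step is large. The earlier compounds differ from one another in more than one place and could not show this, and nothing available here accounts for the size of the step.

Going by these compounds, what a methyl, a methoxy or an amine would do on this same aromatic carbon remains open. Also open, on these data alone, is whether chloro in place of bromo would give a similar step in compounds with a different core.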